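A 3-(trifluoromethyl)phenyl swap on a compound at the limit

The compounds below may be only part of what the source reports. "The series", "measured", "known", "first", "only" and "open" are said of these compounds alone.

Of the compounds shown here, two with a shared core have been measured in a functional assay on HeLa cells (Homo sapiens) for inhibition, read by MTT assay, with a stated time of 72 h; on this read-out lower numbers stand for stronger inhibition and higher numbers for weaker inhibition. In this assay compound 1 `COc1cc(NC(C)CCCNC(=O)NNC(=O)Nc2ccc(F)cc2)c2ncccc2c1` gives >= 250000 nM, which is a limit of the assay and not a number. Compound 2 `COc1cc(NC(C)CCCNC(=O)NNC(=O)Nc2cccc(F)c2)c2ncccc2c1` gives > 250000 nM, and this too is a limit. Compound 2 therefore stands without a number of its own. Among the measured compounds shown here, the only measured step is a step that the two limits leave unreadable from compound 1 to compound 2, and it offers no size to carry forward.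

Compound 3 `COc1cc(NC(C)CCCNC(=O)Nc2cccc(C(F)(F)F)c2)c2ncccc2c1` differs from compound 2 in one place: 3-(trifluoromethyl)phenyl in place of ((3-fluorophenyl)carbamoyl)amino on an amide-type nitrogen. Here 3-(trifluoromethyl)phenyl takes the place of ((3-fluorophenyl)carbamoyl)amino on an amide-type nitrogen. For the measured compounds named here, no measured step covers this exchange, so the expectation rests on the structural change itself and on where compound 2 stands. With compound 2 held at the limit > 250000 nM, any readable result could only lie on the side of stronger inhibition. The expected change in this assay is therefore a clear one in that direction, estimated as an at least 8.3-fold lower number from compound 2 to compound 3 (0.92 log units; beyond the scatter). For compound 3 the expected value is 30000 nM, with an estimated range from 8000 nM to 150000 nM.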

Compound 3, half-maximal inhibitory concentration: 14000 nM
Estimate against measurement, compound 3: 2.1-fold (0.33 log units) above; measured number inside the range.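

The compounds now have a readable number in this assay: putting 3-(trifluoromethyl)phenyl in place of ((3-fluorophenyl)carbamoyl)amino on the amide-type nitrogen gives an at least 17-fold lower number from compound 2 to compound 3 (1.25 log units; beyond the scatter), and the same group in place of ((4-fluorophenyl)carbamoyl)amino gives an at least 17-fold lower number from compound 1 to compound 3 (1.25 log units; beyond the scatter). This position, on an amide-type nitrogen whose other neighbour is a carbonyl carbon, can therefore shift the read-out beyond the scatter, something the earlier exchange of fluorophenyl groups could not show, as that step cannot be read. Both new steps are bounds and not full sizes, and compound 2 gives > 250000 nM, a limit and not a number: the limit of > 250000 nM in this assay, at which 1 of the 3 values shown sits.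

The exchange removes 2 hydrogen-bond donors and 1 hydrogen-bond acceptor and brings in the trifluoromethyl group in a single change, so the compounds shown cannot tell these contributions apart. Plain phenyl or 3-fluorophenyl set directly on the amide-type nitrogen would separate them, and how far the number can move with any other group at this position remains open.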